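A few compounds are considered here, and "the series" means these few. Any claim that something is new, unique, unknown or untested is made for them only; others in the source may bear on it.

Compound 1 `COc1ccc(C2=Nn3c(nnc3C(C)c3ccc(-c4ccccc4)c(F)c3)SC2)cc1` — in a functional assay on MCF7 cells (Homo sapiens) for inhibition, read by sulforhodamine B assay, with a stated time of 72 h (on this read-out lower numbers stand for stronger inhibition and higher numbers for weaker inhibition), compound 1 gives 2600 nM.
Compound 2 `CC(c1ccc(-c2ccccc2)c(F)c1)c1nnc2n1N=C(c1ccc(Cl)cc1)CS2` — in this assay compound 2 gives 8700 nM.

Among the compounds with values here, of the two numbers in this assay, compound 2 holds the highest, and its nearest neighbour is compound 1; the only measured step, a 3.3-fold higher number from compound 1 to compound 2 (0.52 log units; beyond the scatter), is a modest one.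

Compound 3 `CC(c1ccc(-c2ccccc2)c(F)c1)c1nnc2n1N=C(c1ccc(Br)cc1)CS2` has not yet been measured. It differs from compound 2 by bromo in place of chloro on an aromatic carbon. Within the data shown here, no measured step involves a bromo group, and the one step on record, a 3.3-fold higher number from compound 1 to compound 2 (0.52 log units; beyond the scatter), concerns a different exchange on the same ring. The swap of one halogen for a closely related halogen at the same position gives no clear basis to expect a change beyond the scatter in either direction.

Compound 3 is therefore expected to give about 9000 nM in this assay, within a range from 4000 nM to 20000 nM; the expected step is a 1.0-fold higher number from compound 2 to compound 3 (0.01 log units; within the scatter).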

Compound 3, half-maximal inhibitory concentration: 7400 nM
Beside the measured number, compound 3's estimate is 1.2-fold (0.09 log units) above it; the measured number falls inside the stated range.
By their numbers in this assay, from the lowest: compound 1; then compounds 3 and 2 (each within the scatter of the next).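

In this assay, bromo in place of chloro on this six-membered aromatic ring gives a 1.2-fold lower number from compound 2 to compound 3 (0.07 log units; within the scatter), so the two halogens cannot be told apart at this position. Methoxy stays separate from both: a 2.8-fold higher number from compound 1 to compound 3 (0.45 log units; beyond the scatter) sits alongside a 3.3-fold higher number from compound 1 to compound 2 (0.52 log units; beyond the scatter), which shows that the gap seen with chloro is not unique to that one halogen but also appears with bromo. No information is available on why methoxy and the two halogens differ.

Going by these compounds, how fluoro, a hydroxyl group or an amine at this same position would compare with methoxy and the two halogens remains open. On these data alone, it is also open whether the gap between methoxy and the halogens would persist if another part of the shared core were changed.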